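Trimming a Tert-Butyl Group: Expectation Before Measurement

This account rests on a few compounds, and the source may have more. Where it says the series, first, only, none or still open, it means among the compounds named here.

Measured compounds:
compound 1, `CC(C)(C)c1ccc(C(=O)/C=C/C(=O)O)cc1`, 4330 nM
compound 2, `CCCCCCCCCCCCc1ccc(C(=O)/C=C/C(=O)O)cc1`, 4010 nM

Two compounds share a core and differ only in the chain on the aromatic ring. In a functional assay on K562 cells (Homo sapiens) for inhibition, read by MTT assay, with a stated time of 72 h (on this read-out lower numbers stand for stronger inhibition and higher numbers for weaker inhibition), compound 1 gives 4330 nM, and compound 2 gives 4010 nM. Within the data shown here, compound 1 stands at one end of these two numbers, yet its only neighbour, compound 2, sits within the usual scatter of it, so the two are not told apart. The long chain of compound 2 and the tert-butyl group of compound 1 thus come out alike.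

Compound 3, `CC(C)c1ccc(C(=O)/C=C/C(=O)O)cc1`, is not yet measured. It differs from compound 1 by hydrogen in place of methyl on a saturated chain carbon bound to an aromatic carbon and two saturated chain carbons. This is a small change at the edge of the molecule.

Since the two known compounds are alike despite a large difference in chain length, no step beyond the scatter is expected here, in either direction; the expected step from compound 1 to compound 3 is a 1.2-fold higher number from compound 1 to compound 3 (0.06 log units; within the scatter). Compound 3 is estimated at 5000 nM, within 2500 nM to 10000 nM.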

Compound 3, half-maximal inhibitory concentration: 5560 nM
The estimate for compound 3 lay 1.1-fold (0.05 log units) below the measured number; measured number inside the range.
By their numbers in this assay, from the lowest: compounds 2, 1 and 3 (each within the scatter of the next).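

In this assay the change from tert-butyl to isopropyl removes one methyl and leaves everything else in the molecule as it was (a 1.3-fold higher number from compound 1 to compound 3 (0.11 log units; within the scatter)). Unlike the earlier comparison of two quite different chains, this pair isolates a single methyl on a saturated chain carbon bound to an aromatic carbon and two saturated chain carbons, and the two compounds cannot be told apart on this read-out, so losing that one methyl leaves no detectable mark here. No supporting measurement is available to say why the two compounds read alike.

On these data alone, what stays open is how far the trimming can go: an ethyl or a plain methyl in the same place might still read like compound 1 and compound 3, or might finally produce a step beyond the scatter. As far as these compounds go, it is also open whether a group of a different kind at this spot, such as a hydroxyl, an amine or a cyclopropyl ring, would leave the number just as undisturbed.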